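Moving the Chlorine Around a Benzyl Ether

A few compounds are considered here, and "the series" means these few. Any claim that something is new, unique, unknown or untested is made for them only; others in the source may bear on it.

Compound 1, `Cc1ccc(NC(=S)NC(=O)c2ccc(OCc3cccc(F)c3)cc2)cc1-c1nc2ccccc2[nH]1`, gives 86800 nM in a functional assay on MNK45 cells (Homo sapiens) for inhibition, read by MTT assay, with a stated time of 48 h; on this read-out lower numbers stand for stronger inhibition and higher numbers for weaker inhibition.
Compound 2, `O=C(NC(=S)Nc1ccc(Cl)c(-c2nc3ccccc3[nH]2)c1)c1ccc(OCc2ccc(C(F)(F)F)cc2)cc1`, gives 7830 nM in this assay.
Compound 3, `Cc1ccc(NC(=O)NC(=O)c2ccc(OCc3cccc(Cl)c3)cc2)cc1-c1nc2ccccc2[nH]1`, gives 28000 nM in this assay.

Among these three, compound 3 holds the second highest number. Compound 1 sits above it and compound 2 below it, and both of those gaps lie beyond the usual scatter of repeated measurements, so compound 3 stands clearly apart from each of its two neighbours rather than blending with either.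

The next compound, compound 4, `Cc1ccc(NC(=O)NC(=O)c2ccc(OCc3ccccc3Cl)cc2)cc1-c1nc2ccccc2[nH]1`, has the same atoms as compound 3 joined differently: 2-chlorophenyl in place of 3-chlorophenyl on a saturated chain carbon bound to an oxygen on an aromatic ring. Nothing else changes. For the measured compounds named here, no pair of measured compounds differs in just this way, so there is no directly comparable step to lean on, and the three measured compounds differ from one another in several places at once.

With only that to go on, the step from compound 3 to compound 4 in this assay is expected to be small, with no direction that could be told apart from the scatter; the expected step is a 1.1-fold higher number from compound 3 to compound 4 (0.03 log units; within the scatter).

For compound 4, the value in this assay is therefore estimated at 30000 nM, with a plausible range from 9000 nM to 100000 nM.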

Compound 4, half-maximal inhibitory concentration: 21500 nM
Beside the measured number, compound 4's estimate is 1.4-fold (0.14 log units) above it, and the stated range covers the measured number.
By their numbers in this assay, from the lowest: compound 2; then compounds 4 and 3 (each within the scatter of the next); then compound 1.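

Exchanging 3-chlorophenyl for 2-chlorophenyl on a saturated chain carbon bound to an oxygen on an aromatic ring, with nothing else altered, gives a 1.3-fold lower number from compound 3 to compound 4 (0.11 log units; within the scatter) in this assay. For the compounds shown here, this is the first comparison in the set that isolates a single change, since the earlier compounds differ from one another in several places at once, and it shows that these two placements of the chlorine cannot be told apart on this read-out. Nothing in the data at hand offers an explanation for this result.

The compounds shown leave open whether this position tolerates other changes as readily, for instance a methoxy group, a nitrile or an amine in place of the chlorine, or a benzyl group with no substituent at all. Also open, from the compounds shown here alone, is whether the same exchange would read alike in this assay on a compound carrying the thiocarbonyl of compound 1 in place of the carbonyl, which would show whether the result holds beyond this one pair.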